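This account rests on a few compounds, and the source may have more. Where it says the series, first, only, none or still open, it means among the compounds named here.

Measured in a functional assay on MGC-803 cells (Homo sapiens) for inhibition, read by MTT assay, with a stated time of 48 h; on this read-out higher numbers stand for weaker inhibition and lower numbers for stronger inhibition:
- compound 1 `COc1ccc(CNc2cc(OC)c(OC)c(OC)c2)cc1Cl`: 46200 nM
- compound 2 `COc1ccc(CNc2cc(OC)c(OC)c(OC)c2)cc1`: 11400 nM
- compound 3 `COc1ccc(CNc2cc(OC)c(OC)c(OC)c2)cc1N`: not yet measured

Compound 2 holds the lower of the two numbers, 11400 nM, which makes it the stronger inhibitor of this pair. Compound 3 keeps the rest of compound 2 and changes one place: amino in place of hydrogen on an aromatic carbon. This puts amino in place of hydrogen on an aromatic carbon, ortho to a methoxy group.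

Among the compounds with values here, only one measured step touches that carbon, where compound 1 carries chloro: a 4.1-fold lower number from compound 1 to compound 2 (0.61 log units; beyond the scatter). This modest step, beyond the scatter, shows that a change at this carbon can move the number. Chloro is a different group from amino, however, so the direction of that step need not carry over. With so little evidence, a modest step of similar size or smaller is expected, tentatively toward a lower number. The expected change is a 1.9-fold lower number from compound 2 to compound 3 (0.28 log units; within the scatter). For compound 3 the estimated value is 6000 nM, with an expected range from 1200 nM to 30000 nM.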

Compound 3, half-maximal inhibitory concentration: 7970 nM
Estimate against measurement, compound 3: 1.3-fold (0.12 log units) below; the range from low to high includes it.
By their numbers in this assay, from the lowest: compounds 3 and 2 (each within the scatter of the next); then compound 1.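

In this assay an amino group on this aromatic carbon, ortho to a methoxy group, makes a change that stays within the scatter (a 1.4-fold lower number from compound 2 to compound 3 (0.16 log units; within the scatter)), so compound 2 and compound 3 cannot be told apart, even though a hydrogen atom has given way to a group with a nitrogen atom. Swapping chloro for amino at the same carbon gives a modest step beyond the scatter (a 5.8-fold lower number from compound 1 to compound 3 (0.76 log units; beyond the scatter)), and it points the same way as the swap of chloro for hydrogen (a 4.1-fold lower number from compound 1 to compound 2 (0.61 log units; beyond the scatter)). The earlier pair showed only that chloro and hydrogen differ here; now chloro stands apart from both other groups, which makes compound 1 the weakest of the three, and not every change at this carbon moves the number beyond the scatter.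

As far as these compounds go, whether a hydroxyl group, a fluoro group or an acetamide on this carbon would stay level with hydrogen and amino or fall with chloro remains open. No evidence is at hand on what lies behind the difference between chloro and the other two groups.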